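The compounds below may be only part of what the source reports. "The series", "measured", "known", "first", "only" and "open" are said of these compounds alone.

The measured compounds and their values:

Compound 1 `Cc1ccc(NC(=O)C(C)Br)cc1C(=O)NC(N)=O`: in a functional assay on CCRF-CEM cells (Homo sapiens) for antiproliferative activity, read by trypan blue exclusion, with a stated time of 72 h (on this read-out lower numbers stand for stronger inhibition and higher numbers for weaker inhibition), compound 1 gives > 20000 nM, which is a limit of the assay rather than a number.
Compound 2 `Cc1ccc(NC(=O)CBr)cc1C(=O)NC(N)=O`: in this assay compound 2 gives 4760 nM.
Compound 3 `Cc1ccc(C(=O)NC(N)=O)cc1NC(=O)C(C)Cl`: in this assay compound 3 gives > 20000 nM, which is again a limit of the assay.

Compounds 1 and 2 share one core. Going from compound 1 to compound 2 the change is hydrogen in place of methyl on a saturated chain carbon bound to a bromine atom and a carbonyl carbon, and it produced an at least 4.2-fold lower number from compound 1 to compound 2 (0.62 log units; beyond the scatter); the size of this step is known only as a lower bound because compound 1 sits at the limit of > 20000 nM in this assay, at which 2 of the 3 values shown sit.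

Compound 4 `Cc1ccc(C(=O)NC(N)=O)cc1NC(=O)CCl` has not yet been measured. It rests on the core of compound 3; the difference between that core and the core of compound 1 is not broken down here. Going from compound 3 to compound 4 the change is hydrogen in place of methyl on a saturated chain carbon bound to a carbonyl carbon and a chlorine atom. This is the same kind of change as that from compound 1 to compound 2, but the surroundings differ: there the chain carbon was bound to a bromine atom and a carbonyl carbon, here it is bound to a carbonyl carbon and a chlorine atom.

Since an at least 4.2-fold lower number from compound 1 to compound 2 (0.62 log units; beyond the scatter) was at least modest, a step of similar size is expected for compound 4, namely an at least 2.0-fold lower number from compound 3 to compound 4 (0.30 log units; that floor lies within the scatter). Compound 4 is therefore estimated in this assay at 10000 nM, expected to lie between 3000 nM and 30000 nM, with a real chance that only a limit is returned.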

Compound 4, half-maximal inhibitory concentration: 3360 nM
Compound 4: the middle estimate sits 3.0-fold (0.47 log units) above what was measured; measured number inside the range.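

In this assay, hydrogen in place of methyl on a saturated chain carbon bound to a carbonyl carbon and a chlorine atom gives an at least 5.9-fold lower number from compound 3 to compound 4 (0.77 log units; beyond the scatter), the same direction as the change on the chain carbon bound to a bromine atom. Set side by side, the two steps read: the same change on two cores in this assay, an at least 4.2-fold lower number (0.62 log units; beyond the scatter) from compound 1 to compound 2 and an at least 5.9-fold lower number (0.77 log units; beyond the scatter) from compound 3 to compound 4; the limit leaves it open whether they differ. On these data alone, compound 3 gives > 20000 nM, which is a limit of the assay and not a number, so the direction carries from one core to the other here, while the true size of this step stays unknown and two cores make no general rule.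

The compounds shown leave open what an ethyl group or a longer chain in place of the methyl would do on this chain carbon. They also leave open whether the step holds with a fluorine atom, an iodine atom or an amine in place of the bromine or chlorine atom.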